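Swapping Imidazole for Piperidine on a Propyl Linker

The compounds below may be only part of what the source reports. "The series", "measured", "known", "first", "only" and "open" are said of these compounds alone.

Compound 1 `Cn1cc(C2=C(c3nn(CCn4ccnc4)c4ncccc34)C(=O)NC2=O)c2ccccc21`. In a functional assay on KB cells (Homo sapiens) for antiproliferative activity, read by MTT assay, with a stated time of 48 h (on this read-out lower numbers stand for stronger inhibition and higher numbers for weaker inhibition), compound 1 gives > 100000 nM, which is a limit of the assay and not a number.
Compound 2 `Cn1cc(C2=C(c3nn(CCCCn4ccnc4)c4ncccc34)C(=O)NC2=O)c2ccccc21`. In this assay compound 2 gives > 100000 nM, again a limit.
Compound 3 `Cn1cc(C2=C(c3nn(CCCn4ccnc4)c4ncccc34)C(=O)NC2=O)c2ccccc21`. In this assay compound 3 gives > 100000 nM, also a limit.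

Compound 3 therefore stands where every measured compound stands: at the limit of > 100000 nM in this assay, at which 3 of the 3 values shown sit. No value here is a number, so compound 3 cannot be placed above or below compounds 1 and 2.

Compound 4 `Cn1cc(C2=C(c3nn(CCCN4CCCCC4)c4ncccc34)C(=O)NC2=O)c2ccccc21` is not yet measured. It differs from compound 3 by piperidin-1-yl in place of 1H-imidazol-1-yl on a saturated chain carbon, three bonds along the chain from an aromatic nitrogen.

The measured steps that touch compound 3 are a step that the two limits leave unreadable from compound 1 to compound 3 and a step that the two limits leave unreadable from compound 2 to compound 3; both stay unreadable, because each end sits at the limit of > 100000 nM in this assay, at which 3 of the 3 values shown sit. Going by the values given here, none of the measured steps exchanges the ring at the end of the chain, so no step in these data speaks directly to the change from compound 3 to compound 4. Lengthening or shortening the chain left all three compounds at the limit, and there is nothing to suggest that the new ring would move the read-out into a measurable range.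

The expectation is therefore a step of a number no higher from compound 3 to compound 4 (the limit leaves the size open), most likely again only a limit. Compound 4 is estimated at 100000 nM, within 20000 nM to 300000 nM.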

Compound 4, half-maximal inhibitory concentration: 98000 nM
The estimate for compound 4 lay 1.0-fold (0.01 log units) above the measured number, within the range that was stated.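

Going by these compounds alone, compound 4, which carries 3-(piperidin-1-yl)propyl, is the only compound here that gives a number rather than a limit, while the three compounds with an imidazole-ended chain sit together: the limit of > 100000 nM in this assay, at which 3 of the 4 values shown sit. Set against that limit, the exchange of ring can be read only as a floor: an at least 1.0-fold lower number from compound 3 to compound 4 (0.00 log units; that floor lies within the scatter), an at least 1.0-fold lower number from compound 2 to compound 4 (0.00 log units; that floor lies within the scatter), and an at least 1.0-fold lower number from compound 1 to compound 4 (0.00 log units; that floor lies within the scatter). Each floor lies within the usual scatter, so replacing 1H-imidazol-1-yl with piperidin-1-yl is not shown to strengthen inhibition, and the steps among compound 1, compound 2 and compound 3 still cannot be read.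

The compounds shown leave open whether piperidin-1-yl would give a clearly lower number on the shorter 2-(piperidin-1-yl)ethyl chain or on a longer chain. They also leave open whether a different group at the end of the propyl chain, such as a morpholine ring or an open-chain dimethylamino group, would give a number clearly lower than that of compound 4.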